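The source may report more compounds than this note shows. Statements on the series, on what has been measured and on what is new or still open speak of the compounds shown alone.

Measured in a functional assay on RS4-11 cells (Homo sapiens) for inhibition, read by CCK-8 assay, with a stated time of 48 h; on this read-out higher numbers stand for weaker inhibition and lower numbers for stronger inhibition:
- compound 1 `O=C(NCCNS(=O)(=O)c1ccc(-c2ccccc2OCc2cccc(O)c2)s1)Nc1cc(C(F)(F)F)cc(C(F)(F)F)c1`: 3000 nM
- compound 2 `O=[N+]([O-])c1ccc(NC(=S)NCCNS(=O)(=O)c2ccc(-c3ccccc3OCc3cccc(O)c3)s2)cc1`: 10100 nM
- compound 3 `Cc1cc(C)cc(NC(=O)NCCNS(=O)(=O)c2ccc(-c3ccccc3OCc3cccc(O)c3)s2)c1`: 5800 nM

Compound 1 sits at the low end of these numbers. It is level within the scatter with compound 3 and lies beyond the scatter from compound 2.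

Next in this assay is compound 4 `O=C(NCCNS(=O)(=O)c1ccc(-c2ccccc2OCc2ccccc2)s1)Nc1cc(C(F)(F)F)cc(C(F)(F)F)c1`, which differs from compound 1 by hydrogen in place of hydroxy on an aromatic carbon, so that 3-hydroxybenzyl becomes benzyl. All three measured compounds carry the hydroxy, so the data hold no direct measure of its removal.

Among the measured compounds shown here, the only measured step between single-place analogues is a 1.7-fold lower number from compound 2 to compound 3 (0.24 log units; within the scatter). It concerns the group on an amine nitrogen, leaves the hydroxy untouched and stays within the scatter, so it bears on this change only weakly. It sets no size or direction for the new step.

The expectation therefore starts from compound 1 at 3000 nM, with no step beyond the scatter anticipated and the direction left open. The expected change is a 1.2-fold higher number from compound 1 to compound 4 (0.07 log units; within the scatter), a small estimate with real uncertainty. For compound 4 the estimated value is 3500 nM, with an expected range from 1200 nM to 10000 nM.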

Compound 4, half-maximal inhibitory concentration: > 50000 nM
Compound 4: no number, only a limit; the forecaster's own chance of this, stated with the estimate: 5%; at least 14-fold (1.15 log units) between middle value and limit.
By their numbers in this assay, from the lowest: compounds 1, 3 and 2 (each within the scatter of the next, the first and the last beyond it). At a limit, above all of these: compound 4.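

In this assay, the hydroxy on the 3-hydroxybenzyl group proves not to be dispensable in this pair: its replacement by hydrogen gives an at least 16-fold higher number from compound 1 to compound 4 (1.22 log units; beyond the scatter), and no other single change shown reaches a step of this size. Compound 4 gives no number, only a limit, so the step has a lower bound and no upper one: the limit of > 50000 nM in this assay, at which 1 of the 4 values shown sits. Among the compounds shown here, the earlier compounds all carry the hydroxy and differ in the group on an amine nitrogen, where the one readable step, a 1.7-fold lower number from compound 2 to compound 3 (0.24 log units; within the scatter), stays within the scatter, so this aromatic carbon is the first place where a single change separates two compounds by more than the scatter.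

Whether a methoxy, an amine or a carboxylic acid on the same aromatic carbon would keep compound 1 at 3000 nM remains open, so the compounds shown do not say what the hydroxy can be exchanged for. Also open, as far as these compounds go, is whether the same loss follows removal of the hydroxy from compound 2 or compound 3, which carry other groups on the amine nitrogen.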